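This account rests on a few compounds, and the source may have more. Where it says the series, first, only, none or still open, it means among the compounds named here.

Measured so far in a functional assay on MKN-74 cells (Homo sapiens) for antiproliferative activity, with a stated time of 24 h; a higher number here means a weaker inhibitor, a lower number a stronger inhibitor:
compound 1, `NC(=O)c1c(NC(=O)c2ccccc2Cl)sc2c1CCN(C(=S)Nc1ccccc1Br)C2`: 10800 nM
compound 2, `NC(=O)c1c(NC(=O)c2ccccc2Cl)sc2c1CCN(C(=S)Nc1ccc(C(F)(F)F)cc1)C2`: 7090 nM

The two measured compounds share the whole core and differ only in the aryl group on the thiourea nitrogen. In this assay, within the data shown here, compound 2 gives 7090 nM, and its nearest neighbour is compound 1 with 10800 nM; the one step between them, a 1.5-fold lower number from compound 1 to compound 2 (0.18 log units; within the scatter), is within the scatter, so the two numbers cannot be ordered against each other.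

Compound 3, `NC(=O)c1c(NC(=O)c2ccccc2Cl)sc2c1CCN(C(=S)Nc1c(Cl)cccc1Cl)C2`, has not been measured. It differs from compound 2 at the same position: 2,6-dichlorophenyl in place of 4-(trifluoromethyl)phenyl on an amide-type nitrogen. Among the measured compounds shown here, the only step that bears on this change is the aryl swap on that nitrogen, a 1.5-fold lower number from compound 1 to compound 2 (0.18 log units; within the scatter), which left the number within the scatter. For the measured compounds named here, no measured compound carries 2,6-dichlorophenyl at this position, so nothing in the data singles out that group. On this basis the step to compound 3 is expected to stay within the scatter, a 1.3-fold higher number from compound 2 to compound 3 (0.10 log units; within the scatter). Compound 3 is therefore estimated at 9000 nM, with a range from 3500 nM to 25000 nM.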

Compound 3, half-maximal inhibitory concentration: 4020 nM
Estimate against measurement, compound 3: 2.2-fold (0.35 log units) above; measured number inside the range.
By their numbers in this assay, from the lowest: compounds 3, 2 and 1 (each within the scatter of the next, the first and the last beyond it).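

In this assay, the aryl group on the amide-type nitrogen now gives its first step beyond the scatter: a 2.7-fold lower number from compound 1 to compound 3 (0.43 log units; beyond the scatter), a modest change with 2,6-dichlorophenyl in place of 2-bromophenyl. The other new step, a 1.8-fold lower number from compound 2 to compound 3 (0.25 log units; within the scatter), stays within the scatter, so 2,6-dichlorophenyl and 4-(trifluoromethyl)phenyl cannot be ordered against each other, and compound 2 cannot be separated from either compound 1 or compound 3, leaving the gap between compound 1 and compound 3 as the only resolved difference at this position. Nothing measured on these compounds accounts for that difference.

Among these compounds, only three aryl groups are covered at this position, so it remains open whether the number would move further with plain phenyl, a pyridine ring or a non-aromatic group such as cyclohexyl on that nitrogen, or with a carbonyl in place of the thiocarbonyl. The 2-chlorobenzoyl amide and the primary carboxamide of the shared core are constant across all three compounds, so their contribution to the numbers in this assay cannot be read from this set.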